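A Pyrazole in Place of Phenyl on the Piperidine

A few compounds are considered here, and "the series" means these few. Any claim that something is new, unique, unknown or untested is made for them only; others in the source may bear on it.

Compound 1 `O=C(CCN1CCC(c2ccccc2)CC1)N1CCC[C@H]1c1nc2cc(Cl)c(Cl)cc2[nH]1` was tested in an assay on a cell-free system (plasma) for inhibition of lysosomal Pro-X carboxypeptidase (Mus musculus); a higher number here means a weaker inhibitor, a lower number a stronger inhibitor. In this assay compound 1 gives > 10000 nM, which is a limit of the assay rather than a number. Its companion compound 2 `O=C(CCN1CCN(c2ccccc2)CC1)N1CCC[C@H]1c1nc2cc(Cl)c(Cl)cc2[nH]1` was run alongside. In this assay compound 2 gives > 10000 nM, again a limit and not a number. Among the compounds with values here, compound 1 thus stands at the limit of > 10000 nM in this assay, at which 2 of the 2 values shown sit, and no measured step between the two compounds can be quantified. The unmeasured compound 3 `O=C(CCN1CCC(c2cc[nH]n2)CC1)N1CCC[C@H]1c1nc2cc(Cl)c(Cl)cc2[nH]1` differs from compound 1 in one place: 1H-pyrazol-3-yl in place of phenyl on a saturated ring carbon. Within the data shown here, because no step between measured compounds is available, the step is expected to be a step that the limit leaves unreadable from compound 1 to compound 3 in this assay, that is, none beyond the scatter. Compound 3 is therefore expected to come out at about 20000 nM, within a range from 5000 nM to 80000 nM, most probably reported again only as a limit.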

Compound 3, half-maximal inhibitory concentration: 290 nM
Compound 3: middle estimate off by 69-fold (1.84 log units), on the high side; measured number below the stated range.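

The group on this saturated ring carbon turns out to decide whether the series registers at all in this assay: 1H-pyrazol-3-yl in place of phenyl gives an at least 34-fold lower number from compound 1 to compound 3 (1.53 log units; beyond the scatter). The earlier compounds gave no readable number, so this position had shown nothing until now; compound 3 is the first compound here with a true value and gives a starting point for reading further changes. The step can only be given as a minimum, and its full size remains unknown, because compound 1 stands at a limit of the assay and not at a number: the limit of > 10000 nM in this assay, at which 2 of the 3 values shown sit.

The compounds shown do not separate the effect of the smaller five-membered ring from that of its nitrogens or its hydrogen-bond donor. A 1-methyl-1H-pyrazol-3-yl, a pyridine ring or a carboxylic acid at the same carbon would bear on that question.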